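Bis(indolyl)methanes: hydroxyphenyl to dimethoxyphenyl step

The source may hold more compounds than are shown below. What is called first, only, known or untested is meant among the compounds shown, and "the series" means these compounds.

Measured so far:
compound 1, `c1ccc(C(c2c[nH]c3ccccc23)c2c[nH]c3ccccc23)cc1`: 21800 nM
compound 2, `Oc1cccc(C(c2c[nH]c3ccc(Br)cc23)c2c[nH]c3ccc(Br)cc23)c1`: 3900 nM

In a functional assay on HeLa cells (Homo sapiens) for inhibition, read by MTT assay, with a stated time of 48 h (on this read-out higher numbers stand for weaker inhibition and lower numbers for stronger inhibition), compound 2 stands at the lowest of the two numbers, with compound 1 the nearest, beyond the scatter. Compound 3, `COc1ccc(C(c2c[nH]c3ccc(Br)cc23)c2c[nH]c3ccc(Br)cc23)c(OC)c1`, is not yet measured; it differs from compound 2 by 2,4-dimethoxyphenyl in place of 3-hydroxyphenyl on a saturated chain carbon bound to two aromatic carbons. Among the measured compounds shown here, no single-change step between measured compounds is available, and the two measured compounds differ at more than one place, so the expectation rests on compound 2 alone. For compound 3 a modest step toward weaker inhibition is expected, a 1.8-fold higher number from compound 2 to compound 3 (0.25 log units; within the scatter), though a value within the scatter is also plausible. The estimate for compound 3 is 7000 nM, in the range 2000 nM to 25000 nM.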

Compound 3, half-maximal inhibitory concentration: 63200 nM
Compound 3: middle estimate off by 9.0-fold (0.96 log units), on the low side; the measured number lies above the stated range.
By their numbers in this assay, from the lowest: compound 2; then compound 1; then compound 3.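

In this assay the swap of 3-hydroxyphenyl for 2,4-dimethoxyphenyl on the saturated chain carbon bound to two aromatic carbons gives a 16-fold higher number from compound 2 to compound 3 (1.21 log units; beyond the scatter) and so marks this position as sensitive to the aryl group it carries. Among the compounds shown here, this single-change step is the first; compound 1 and compound 2 differ at more than one place and could not show it. Nothing measured here explains the step.

Going by these compounds, the step removes the hydroxyl and adds both methoxy groups at once, so their separate contributions remain open. Also open, on these data alone, is how a phenyl ring carrying an amine or a carboxylic acid would behave at this position.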